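Lengthening the Chain to a Phenyl End

The source may hold more compounds than are shown below. What is called first, only, known or untested is meant among the compounds shown, and "the series" means these compounds.

Three compounds share one core and differ only in the chain hanging from the ring amine nitrogen. In an in vitro functional assay on HEK ts201 cells for antagonist activity at Neuronal acetylcholine receptor; alpha4/beta2 (Homo sapiens), read by fluorescence and calcium flux (on this read-out lower numbers stand for stronger inhibition and higher numbers for weaker inhibition), compound 1 `CC1CC(=O)N(c2ccccc2C(=O)OCC2CCCN(CCCCCc3ccccc3)C2)C1=O` gives 24500 nM. Compound 2 `CC1CC(=O)N(c2ccccc2C(=O)OCC2CCCN(CCCCOc3ccccc3)C2)C1=O` gives 1700 nM in this assay. Compound 3 `CC1CC(=O)N(c2ccccc2C(=O)OCC2CCCN(CCCC3CCCCC3)C2)C1=O` gives 14500 nM in this assay, the second highest of the three numbers; it lies close to compound 1, since a 1.7-fold lower number from compound 1 to compound 3 (0.23 log units; within the scatter), whereas an 8.5-fold higher number from compound 2 to compound 3 (0.93 log units; beyond the scatter).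

Compound 4 `CC1CC(=O)N(c2ccccc2C(=O)OCC2CCCN(CCCCCCc3ccccc3)C2)C1=O` has not yet been measured. Its change from compound 3 is 3-phenylpropyl in place of cyclohexyl on a saturated chain carbon, three bonds along the chain from an amine nitrogen in a ring. For the measured compounds named here, two measured steps bear on this. First, a 1.7-fold lower number from compound 1 to compound 3 (0.23 log units; within the scatter), so swapping a saturated ring for an aromatic one on a plain carbon chain did not move the number clearly. Second, an 8.5-fold higher number from compound 2 to compound 3 (0.93 log units; beyond the scatter), but there the aromatic ring was joined through oxygen, which compound 4 lacks. Because compound 1, whose ring also sits on a carbon chain, gives 24500 nM, only a small step is expected: a 1.4-fold higher number from compound 3 to compound 4 (0.14 log units; within the scatter). Compound 4 is therefore estimated to give 20000 nM, in a range from 6000 nM to 60000 nM.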

Compound 4, half-maximal inhibitory concentration: 29500 nM
Compound 4: the middle estimate sits 1.5-fold (0.17 log units) below what was measured, and the stated range covers the measured number.
By their numbers in this assay, from the lowest: compound 2; then compounds 3, 1 and 4 (each within the scatter of the next, the first and the last beyond it).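

In this assay, replacing cyclohexyl with 3-phenylpropyl at this position gives a 2.0-fold higher number from compound 3 to compound 4 (0.31 log units; beyond the scatter), so the longer chain ending in a phenyl ring does not bring a lower number than the shorter chain ending in a saturated ring. Adding one more carbon to the all-carbon chain does not separate the two phenyl compounds, with a 1.2-fold higher number from compound 1 to compound 4 (0.08 log units; within the scatter). The oxygen-linked chain stands further apart, with a 17-fold higher number from compound 2 to compound 4 (1.24 log units; beyond the scatter), and among these four compounds only compound 2 is clearly set apart from all the others.

Nothing shown explains why the oxygen-linked chain differs from the all-carbon chains. Going by these compounds, it also remains open whether a sulfur atom or an amine at the oxygen's place in the chain would give a number as low as that of compound 2.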